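A butyl swap on a benzoyl thiourea

The source may hold more compounds than are shown below. What is called first, only, known or untested is meant among the compounds shown, and "the series" means these compounds.

Compound 1 `O=[N+]([O-])c1ccc(N/N=C(/c2ccc(O)cc2)c2cccc3ccccc23)c([N+](=O)[O-])c1`: 6780 nM
Compound 2 `O=C1/C(=C/c2ccc(F)cc2)CN(C(=S)NC(=O)c2ccccc2)C/C1=C\c1ccc(F)cc1`: < 10000 nM (a limit of the assay)
Compound 3 `Cc1ccc(/C=C2\CN(C(=S)NC(=O)c3ccccc3)C/C(=C\c3ccc(C)cc3)C2=O)cc1`: < 10000 nM (a limit of the assay)

All of these values come from a functional assay on DLD-1 cells (Homo sapiens) for antiproliferative activity, read by MTT assay, with a stated time of 48 h (on this read-out higher numbers stand for weaker inhibition and lower numbers for stronger inhibition), and only compound 1 has a true number. Compound 3 stands at a limit and not at a number (< 10000 nM). Compound 2 shares that position, and the series as a whole shows the limit of < 10000 nM in this assay, at which 2 of the 3 values shown sit, with nothing firmer for this core.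

Compound 4 `CCCCNC(=S)N1C/C(=C\c2ccc(C)cc2)C(=O)/C(=C/c2ccc(C)cc2)C1` keeps the shared core of compound 3 and carries butyl in place of benzoyl on an amide-type nitrogen as its one difference. Going by the values given here, no measured pair shows what this swap does. No step beyond the usual scatter is expected in this assay and no direction can be argued with confidence. The only anchor for this expectation is compound 3 with its limit of the assay (< 10000 nM). The estimate amounts to an expected step that the limit leaves unreadable from compound 3 to compound 4 when set against that limit. Compound 4 is expected to read 6000 nM with an estimated range from 2000 nM to 15000 nM in this assay when measured.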

Compound 4, half-maximal inhibitory concentration: < 10000 nM
Compound 4: only a limit was reported; the forecaster's own chance of this, stated with the estimate: 45%; the middle value is on the limit's open side.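

In this assay, going by these compounds alone, compound 3 and compound 4 both stand at a limit of the assay and not at a number, so no step between them can be read. The series stays where it was: the limit of < 10000 nM in this assay, at which 3 of the 4 values shown sit. From the compounds shown here alone, what butyl in place of benzoyl does to the true potency of compound 4 remains open.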